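Extending the butyl chain of compound 3

This account rests on a few compounds, and the source may have more. Where it says the series, first, only, none or still open, it means among the compounds named here.

Measured so far in a functional assay on HT-29 cells (Homo sapiens) for antiproliferative activity, read by sulforhodamine B assay, with a stated time of 48 h; a higher number here means a weaker inhibitor, a lower number a stronger inhibitor:
- compound 1 `CCc1ccccc1NS(=O)(=O)c1ccc(N2CCNC2=O)cc1`: 240 nM
- compound 2 `O=C1NCCN1c1ccc(S(=O)(=O)Nc2ccc(C3CCCCC3)cc2)cc1`: > 1000 nM, a limit of the assay
- compound 3 `CCCCc1ccc(NS(=O)(=O)c2ccc(N3CCNC3=O)cc2)cc1`: 610 nM

Of the two actual numbers, compound 3 has the higher, and its gap to compound 1 lies beyond the scatter. Next comes compound 4 `CCCCCCCc1ccc(NS(=O)(=O)c2ccc(N3CCNC3=O)cc2)cc1`, with this change: propyl in place of hydrogen on a saturated chain carbon, four bonds along the chain from an aromatic carbon.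

Going by the values given here, one measured step bears on it: an at least 1.6-fold lower number from compound 2 to compound 3 (0.21 log units; that floor lies within the scatter). That step has only a floor, and the floor lies within the scatter, so it sets no firm size. Only a small rise in this assay, within the scatter, is therefore expected. The expected change is a 1.3-fold higher number from compound 3 to compound 4 (0.12 log units; within the scatter). For compound 4 the estimated value is 800 nM, with an expected range of 300 nM to 2500 nM.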

Compound 4, half-maximal inhibitory concentration: > 1000 nM
Compound 4 ended at the assay's limit; the forecaster's own chance of this, stated with the estimate: 35%; at least 1.2-fold (0.09 log units) between middle value and limit.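

In this assay the propyl addition gives an at least 1.6-fold higher number from compound 3 to compound 4 (0.21 log units; that floor lies within the scatter) and so brings no measurable gain over butyl, though the size of that step stays unfixed. With heptyl, as with cyclohexyl in compound 2, the series reaches the assay's limit, and the step from compound 2 to compound 4 cannot be read: the limit of > 1000 nM in this assay, at which 2 of the 4 values shown sit.

Open, from the compounds shown here alone, is how pentyl or hexyl would read in place of heptyl, with values possibly still below the limit. Also open, going by these compounds, is whether an amine or a carboxylic acid on the chain would bring compound 4 back into the measurable range.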